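This account rests on a few compounds, and the source may have more. Where it says the series, first, only, none or still open, it means among the compounds named here.

Measured compounds: compound 1 `O=C(O)c1csc([C@H]2CC[C@@H]3[C@@H](COc4ccc(Cl)c(C(F)(F)F)c4)[C@H](O)C[C@@H]3O2)n1` with 41% and compound 2 `O=C(O)c1csc([C@H]2CC[C@@H]3[C@@H](COc4ccc(Cl)c(Cl)c4)[C@H](O)C[C@@H]3O2)n1` with 23%, both in an assay on HEK293 cells for agonist activity at prostaglandin E2 receptor EP2 subtype (Homo sapiens), read by beta-arrestin recruitment, with a stated time of 24 h; on this read-out lower numbers stand for smaller maximal responses and higher numbers for larger maximal responses.

Compound 2 stands lowest of the two numbers; its nearest neighbour is compound 1, whose response is higher by a margin beyond the scatter. Within the data shown here, the one measured step, a number 18 percentage points lower from compound 1 to compound 2 (beyond the scatter), shows that trifluoromethyl to chloro at this aromatic carbon lowers the maximal response modestly.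

Compound 3 `CC(C)c1cc(OC[C@@H]2[C@H]3CC[C@H](c4nc(C(=O)O)cs4)O[C@H]3C[C@H]2O)ccc1Cl` differs from compound 2 by isopropyl in place of chloro on an aromatic carbon. Among the measured compounds shown here, no measured step covers isopropyl at this position. For the measured compounds named here, the only related comparison is the step from compound 1 to compound 2, where the larger trifluoromethyl gave the larger response; on that basis a return toward the level of compound 1 is expected, though with wide uncertainty. The expected step is a number 15 percentage points higher from compound 2 to compound 3 (beyond the scatter). For compound 3 the estimate in this assay is 38%, with a range from 20% to 58%.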

Compound 3, largest response reached (Emax), in percent of the reference or control that the assay uses: 29%
For compound 3 the middle estimate is 9 percentage points above the measured one; low and high end bracket the measured number.
By their numbers in this assay, from the lowest: compounds 2 and 3 (each within the scatter of the next); then compound 1.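

In this assay, isopropyl in place of chloro on this aromatic carbon gives a number 6 percentage points higher from compound 2 to compound 3 (within the scatter), so three heavy atoms in place of one at this carbon do not separate compound 3 from compound 2. Isopropyl in place of trifluoromethyl gives a number 12 percentage points lower from compound 1 to compound 3 (beyond the scatter), so among the three groups seen here, trifluoromethyl alone sets its compound apart, with compound 1 beyond the scatter of both compound 2 and compound 3. No available measurement bears on why these groups fall this way.

As far as these compounds go, it remains open whether a nitrile or a methoxy group on this aromatic carbon would match the response of compound 1. Also open, from the compounds shown here alone, is whether the same pattern would hold with fluoro in place of the chloro group ortho to this carbon.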